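Pyrrolidine amide replaced by plain piperidine on the ring amine

The source may report more compounds than this note shows. Statements on the series, on what has been measured and on what is new or still open speak of the compounds shown alone.

Measured so far:
compound 1 `Cc1nn([C@H](C)c2ccc(Cl)cc2Cl)c2nc(N3CC[C@H](N4CCC[C@H]4C(N)=O)[C@H](C)C3)cnc12` — 170 nM
compound 2 `Cc1nn([C@H](C)c2ccc(Cl)cc2Cl)c2nc(N3CC[C@H](N4CCC[C@H]4CCC(N)=O)[C@H](C)C3)cnc12` — 37 nM
compound 3 `Cc1nn([C@H](C)c2ccc(Cl)cc2Cl)c2nc(N3CC[C@H](N4CCCCC4)[C@H](C)C3)cnc12` — not yet measured

In a functional assay on cells for antagonist activity at C-C chemokine receptor type 4 (Homo sapiens), read by fluorescence and calcium flux, with stated times of 2.5 s and 45 s (on this read-out higher numbers stand for weaker inhibition and lower numbers for stronger inhibition), compound 1 gives 170 nM and compound 2 gives 37 nM; the step is a 4.6-fold lower number from compound 1 to compound 2 (0.66 log units; beyond the scatter). Compound 2 thus holds the lower of the two numbers. Compound 3 carries the change (piperidin-1-yl in place of 2-(2-carbamoylethyl)pyrrolidin-1-yl on a saturated ring carbon). For the measured compounds named here, no measured step removes the amide outright; the single step of a 4.6-fold lower number from compound 1 to compound 2 (0.66 log units; beyond the scatter) only shows that moving it shifts the number beyond the scatter, so removing it is expected to raise the number. Compound 3 is therefore estimated at 300 nM, within 60 nM to 1500 nM, an expected step of an 8.1-fold higher number from compound 2 to compound 3 (0.91 log units; beyond the scatter).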

Compound 3, half-maximal inhibitory concentration: 42 nM
Estimate against measurement, compound 3: 7.1-fold (0.85 log units) above; measured number below the stated range.
By their numbers in this assay, from the lowest: compounds 2 and 3 (each within the scatter of the next); then compound 1.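

In this assay, the amide-free piperidin-1-yl group on this saturated ring carbon matches the 2-(2-carbamoylethyl)pyrrolidin-1-yl group (a 1.1-fold higher number from compound 2 to compound 3 (0.06 log units; within the scatter)), so the amide is not required for a number at this level. Against the 2-carbamoylpyrrolidin-1-yl group, the same replacement gives a clear gain (a 4.0-fold lower number from compound 1 to compound 3 (0.61 log units; beyond the scatter)). Nothing available here explains either step.

Unsubstituted pyrrolidin-1-yl would separate ring size from loss of the side chain, and this remains open. Also open, going by these compounds, is how a carboxylic acid or an amine at the end of the chain would read in this assay.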